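Fluoro for Methoxy on the Aryl Ring of Compound 1

The source may hold more compounds than are shown below. What is called first, only, known or untested is meant among the compounds shown, and "the series" means these compounds.

Within the data shown here, compound 1 `C=CC1=C(C(=O)NCCCCC)C(c2ccc(OC)cc2)OC1` is the only member of this small set with a number rather than a limit: in a functional assay on A549 cells (Homo sapiens) for cytotoxicity, read by MTT assay, with a stated time of 24 h (on this read-out higher numbers stand for weaker inhibition and lower numbers for stronger inhibition), compound 1 gives 36500 nM. Compound 2 `C=CC1=C(C(=O)NC(C)(C)C)C(c2ccc(OC)cc2)OC1` reaches only the limit of > 100000 nM in this assay. Compound 3 `C=CC1=C(C(=O)NCc2ccc(C)cc2)C(c2ccc(OC)cc2)OC1` likewise sits at the limit of > 100000 nM in this assay. The step of an at least 2.7-fold higher number from compound 1 to compound 2 (0.43 log units; beyond the scatter) and the step of an at least 2.7-fold higher number from compound 1 to compound 3 (0.43 log units; beyond the scatter) both concern the amide side of the shared core, and the step that the two limits leave unreadable from compound 2 to compound 3 cannot be sized because of the limit of > 100000 nM in this assay, at which 2 of the 3 values shown sit.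

Compound 4 `C=CC1=C(C(=O)NCCCCC)C(c2ccc(F)cc2)OC1` differs from compound 1 elsewhere: fluoro in place of methoxy on an aromatic carbon. Among the measured compounds shown here, no measured step touches this aromatic carbon, so the two steps on the amide nitrogen give no guide to it, and the expectation rests on compound 1 alone. The step of a 1.1-fold higher number from compound 1 to compound 4 (0.04 log units; within the scatter) is therefore expected to stay within the scatter. Compound 4 is estimated at 40000 nM in this assay, between 15000 nM and 100000 nM.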

Compound 4, half-maximal inhibitory concentration: > 100000 nM
Compound 4 ended at the assay's limit; the forecaster's own chance of this, stated with the estimate: 25%; middle value at least 2.5-fold (0.39 log units) from the limit.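

With fluoro in place of methoxy on an aromatic carbon, the result is an at least 2.7-fold higher number from compound 1 to compound 4 (0.43 log units; beyond the scatter). The earlier steps shown here all lay on the amide side, whereas here the pentyl amide is held constant and a change on the aromatic ring, para to a large group, alone moves the read-out in this assay. Compound 4 stands at a limit of the assay and not at a number, so the full size of this step stays unknown, and steps between compounds at the limit cannot be read: the limit of > 100000 nM in this assay, at which 3 of the 4 values shown sit.

With only methoxy and fluoro shown on this aromatic carbon, the compounds leave open how chloro, hydroxy or an amine there would read. They also leave open whether a longer chain than pentyl on the amide nitrogen would shift the number of compound 1.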